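The source may report more compounds than this note shows. Statements on the series, on what has been measured and on what is new or still open speak of the compounds shown alone.

Of the compounds shown here, three have been measured so far in a functional assay on SMMC-7721 cells (Homo sapiens) for cytotoxicity, read by MTT assay, with a stated time of 4 days; a higher number here means a weaker inhibitor, a lower number a stronger inhibitor. Compound 1 `C=C1C[C@]23C[C@@]1(O)CC[C@H]2c1ccc(OS(=O)(=O)c2ccc(C)cc2)c(C)c1[C@@H]3Cn1cc(-c2ccc(C)cc2)nn1` gives > 20000 nM, which is a limit of the assay rather than a number. Compound 2 `Cc1c(O)ccc2c1[C@H](Cn1cc(-c3ccc(Cl)cc3)nn1)[C@@]13CC(=O)[C@@](C)(CC[C@@H]21)C3` gives > 20000 nM, again only a limit. Compound 3 `C=C1C[C@]23C[C@@]1(O)CC[C@H]2c1ccc(O)c(C)c1[C@@H]3Cn1cc(-c2ccc(C(F)(F)F)cc2)nn1` gives > 20000 nM, also a limit. Among the compounds with values here, all three therefore sit at the limit of > 20000 nM in this assay, at which 3 of the 3 values shown sit, and no measured pair shows any step at all. Compound 4 `C=C1C[C@]23C[C@@]1(O)CC[C@H]2c1ccc(O)c(C)c1[C@@H]3Cn1cc(-c2ccc(C)cc2)nn1` differs from compound 3 in one place: methyl in place of trifluoromethyl on an aromatic carbon. Nothing measured shows what this change does. With compound 3 sitting at the limit of > 20000 nM in this assay, at which 3 of the 3 values shown sit, the change is expected to leave matters where they are, no step beyond the scatter, estimated as a step that the limit leaves unreadable from compound 3 to compound 4. Compound 4 is expected to come out near 30000 nM, within 10000 nM to 100000 nM, and most probably reported once more as a limit.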

Compound 4, half-maximal inhibitory concentration: > 20000 nM
Compound 4 ended at the assay's limit; the forecaster's own chance of this, stated with the estimate: 85%; the middle value does not contradict the limit.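

Compound 4, like compound 1 and compound 3, sits at a limit in this assay, so neither step to compound 4 can be read. The compounds shown leave open what true value any of them has.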